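The compounds below may be only part of what the source reports. "The series", "measured", "known", "first", "only" and "open" are said of these compounds alone.

Measured so far in an assay on mitochondria from L6 cells (Rattus norvegicus) for activation, with a stated time of 90 min; on this read-out higher numbers stand for an effect only at larger amounts of compound and lower numbers for an effect already at smaller amounts:
compound 1 `Fc1ccc(Nc2nc3nonc3nc2Nc2ccccc2F)cc1` gives 2300 nM
compound 2 `Cc1ccc(Nc2nc3nonc3nc2Nc2ccccc2F)cc1` gives 2100 nM
compound 3 `O=C(Nc1ccc(Nc2nc3nonc3nc2Nc2ccccc2F)cc1)C(F)(F)F` gives 4100 nM

Compound 3 carries the highest of the three numbers, yet its distance to compound 1 and to compound 2 is within the scatter, so no order among the three can be read from this assay. Compound 4 `Fc1ccccc1Nc1nc2nonc2nc1Nc1ccc(C(F)(F)F)cc1` is the next member; it differs from compound 3 as follows: trifluoromethyl in place of ((trifluoromethyl)carbonyl)amino on an aromatic carbon. All three measured steps change the group at the same place on the same ring, and each stayed within the scatter: a 1.1-fold lower number from compound 1 to compound 2 (0.04 log units; within the scatter), a 1.8-fold higher number from compound 1 to compound 3 (0.25 log units; within the scatter), a 2.0-fold higher number from compound 2 to compound 3 (0.29 log units; within the scatter). On that basis no step beyond the scatter is expected in this assay, in either direction, and compound 4 is estimated at 2800 nM (range 1200 nM to 6500 nM), the expected step being a 1.5-fold lower number from compound 3 to compound 4 (0.17 log units; within the scatter).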

Compound 4, half-maximal effective concentration: 270 nM
Beside the measured number, compound 4's estimate is 10-fold (1.02 log units) above it; the measured number lies below the stated range.
By their numbers in this assay, from the lowest: compound 4; then compounds 2, 1 and 3 (each within the scatter of the next).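

Trifluoromethyl on this aromatic carbon gives the first steps beyond the scatter in this assay: a 15-fold lower number from compound 3 to compound 4 (1.18 log units; beyond the scatter), a 7.8-fold lower number from compound 2 to compound 4 (0.89 log units; beyond the scatter) and an 8.5-fold lower number from compound 1 to compound 4 (0.93 log units; beyond the scatter). The position therefore does respond to its group, and a trifluoromethyl end alone does not explain the result, since ((trifluoromethyl)carbonyl)amino carries one and stays with fluoro and methyl. Nothing available explains these steps.

Open, on these data alone, is whether a nitrile, a chloro or a trifluoromethoxy group at this place would match trifluoromethyl, or whether that group stands alone.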